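Amino for hydrogen on two isomeric cores

The compounds below may be only part of what the source reports. "The series", "measured", "known", "first", "only" and "open" are said of these compounds alone.

Compound 1 `ClCc1ccc(Cn2cnc3c(Cl)ncnc32)cc1` and compound 2 `Nc1nc(Cl)c2ncn(Cc3ccc(CCl)cc3)c2n1` share one core. In a functional assay on SK-MEL-5 cells (Homo sapiens) for cytotoxicity, read by sulforhodamine B assay, with a stated time of 48 h (a higher number here means a weaker inhibitor of growth, a lower number a stronger inhibitor of growth), compound 1 gives 20900 nM, and compound 2 gives 31000 nM. The change between them, (amino in place of hydrogen on an aromatic carbon), made a 1.5-fold higher number from compound 1 to compound 2 (0.17 log units; within the scatter). Compound 3 `ClCc1ccccc1Cn1cnc2c(Cl)ncnc21` is built from the same atoms as compound 1, joined differently; the difference between the two cores is not broken down here. In this assay compound 3 gives 2880 nM, the lowest of the three numbers and beyond the scatter from both compound 1 and compound 2. Compound 4 `Nc1nc(Cl)c2ncn(Cc3ccccc3CCl)c2n1` carries the same change on the core of compound 3: amino in place of hydrogen on an aromatic carbon. The step from compound 3 to compound 4 is expected to be a 1.5-fold higher number from compound 3 to compound 4 (0.16 log units; within the scatter), because the identical change gave a 1.5-fold higher number from compound 1 to compound 2 (0.17 log units; within the scatter). Compound 4 is therefore estimated at 4200 nM in this assay, with a range from 1600 nM to 11000 nM.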

Compound 4, concentration for total growth inhibition: 26300 nM
Compound 4: the middle estimate sits 6.3-fold (0.80 log units) below what was measured; the measured number lies above the stated range.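

In this assay, amino in place of hydrogen on an aromatic carbon gave a 9.1-fold higher number from compound 3 to compound 4 (0.96 log units; beyond the scatter). The size of the step did not carry from one core to the other: the same change on two cores in this assay, a 1.5-fold higher number (0.17 log units; within the scatter) from compound 1 to compound 2 and a 9.1-fold higher number (0.96 log units; beyond the scatter) from compound 3 to compound 4, 6.2-fold (0.79 log units) apart, beyond the scatter of two such steps. The step on one core is therefore a poor guide to the step on the other in this series, though these two pairs do not show what separates the cores, nor how the change would behave on any further core.

As far as these compounds go, whether a methylamino or a methoxy group on the same aromatic carbon would follow the step seen on the core of compound 1 or that seen on the core of compound 3 remains open. From the compounds shown here alone, whether the gap between the two steps holds in other cell lines is also open.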